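Replacing the Chloro Substituent with a Methylpyrazole Ring

The source may hold more compounds than are shown below. What is called first, only, known or untested is meant among the compounds shown, and "the series" means these compounds.

Compound 1 `COc1cc(-c2ccnc3cc(-c4ccc(Cl)cc4)nn23)cc(OC)c1OC` is the starting point of this step. In a functional assay on A549 cells (Homo sapiens) for inhibition, read by CCK-8 assay, with a stated time of 48 h (a higher number here means a weaker inhibitor, a lower number a stronger inhibitor), compound 1 gives 3070 nM, the highest of the two numbers given; the nearest is compound 3 `COc1cc(-c2ccnc3cc(-c4cn(C)c5ccccc45)nn23)cc(OC)c1OC`, which gives 1340 nM. Compound 2 `COc1cc(-c2ccnc3cc(-c4cccc(C#N)c4)nn23)cc(OC)c1OC` reaches only a limit of the assay in this assay, > 10000 nM (the limit of > 10000 nM in this assay, at which 1 of the 3 values shown sits). The measured steps that change the group on the aromatic carbon of the shared core are an at least 3.2-fold higher number from compound 1 to compound 2 (0.51 log units; beyond the scatter) and a 2.3-fold lower number from compound 1 to compound 3 (0.36 log units; beyond the scatter), and between those two compounds an at least 7.4-fold lower number from compound 2 to compound 3 (0.87 log units; beyond the scatter). Compound 4 `COc1cc(-c2ccnc3cc(-c4ccc(-c5cnn(C)c5)cc4)nn23)cc(OC)c1OC` is not yet measured; it differs from compound 1 by 1-methyl-1H-pyrazol-4-yl in place of chloro on an aromatic carbon. Among the compounds with values here, no measured step exchanges the chloro for a 1-methyl-1H-pyrazol-4-yl, so the nearest guides are the gain seen with the larger 1-methyl-1H-indol-3-yl in compound 3 and the loss seen with the 3-cyanophenyl in compound 2. The entering ring sits para to a large group rather than where the nitrile stood, so the step from compound 1 is expected to stay small, a 1.5-fold lower number from compound 1 to compound 4 (0.19 log units; within the scatter). Compound 4 is therefore estimated at 2000 nM, within 600 nM to 7000 nM.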

Compound 4, half-maximal inhibitory concentration: 1150 nM
The estimate for compound 4 lay 1.7-fold (0.24 log units) above the measured number; measured number inside the range.
By their numbers in this assay, from the lowest: compounds 4 and 3 (each within the scatter of the next); then compound 1. At a limit, above all of these: compound 2.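

In this assay, the step of a 2.7-fold lower number from compound 1 to compound 4 (0.43 log units; beyond the scatter) shows that this carbon, para to a large group, accepts the much larger 1-methyl-1H-pyrazol-4-yl in place of chloro and that the number falls beyond the scatter. The earlier compounds shown here exchanged the whole group on the shared core, whereas this change keeps the six-membered aromatic ring of compound 1 and alters only its substituent, and it reaches the same level as an exchange of that whole ring: compound 4 gives 1150 nM and compound 3 gives 1340 nM, two values within the scatter of each other. Nothing measured here gives a reason for the lower number of compound 4.

Whether the gain needs the pyrazole ring itself remains open, since the compounds shown do not tell what an amine, a morpholine ring or a carboxylic acid on that carbon would do, nor what the methyl on the pyrazole contributes. Also open, going by these compounds, is whether the same order of compounds would hold on cells other than this one line.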